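A few compounds are considered here, and "the series" means these few. Any claim that something is new, unique, unknown or untested is made for them only; others in the source may bear on it.

Working notes on the series. For the measured compounds named here, compound 2 `COC(=O)CC1CCN(C[C@H]2CN(c3ccc(-n4cc(-c5ccccn5)cn4)c(F)c3)C(=O)O2)CC1` stands lowest of the two numbers so far in a physicochemical assay for lipophilicity, read by HPLC, measured as octanol-water partition; on this read-out lower numbers stand for lower lipophilicity and higher numbers for higher lipophilicity: compound 2 gives 1.78, while compound 1 `O=C1O[C@@H](CN2CCCCC2)CN1c1ccc(-n2cc(-c3ccccn3)cn2)c(F)c1` gives 3.1. Going by the values given here, the one measured step is a number 1.32 log units lower from compound 1 to compound 2 (beyond the scatter), a large drop beyond the scatter.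

Compound 3 `O=C1O[C@@H](CSc2cccs2)CN1c1ccc(-n2cc(-c3ccccn3)cn2)c(F)c1` differs from compound 2 as follows: (thiophen-2-yl)sulfanyl in place of 4-((methoxycarbonyl)methyl)piperidin-1-yl on a saturated chain carbon bound to a saturated ring carbon. Among the compounds with values here, no measured step covers a change of this kind; the step from compound 1 to compound 2 concerns only the (methoxycarbonyl)methyl group on the ring, and the ring itself is not removed anywhere among the measured compounds. Within the data shown here, the estimate below therefore rests on no measured precedent and is held loosely. In this assay a sizeable rise from compound 2 is expected, placing compound 3 above compound 1 as well. The expected step is a number 2.22 log units higher from compound 2 to compound 3 (beyond the scatter). Compound 3 is estimated at 4, with a range from 3.2 to 4.8.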

Compound 3, partition coefficient: 4.29
Compound 3: middle estimate off by 0.29 log units, on the low side; low and high end bracket the measured number.
By their numbers in this assay, from the lowest: compound 2; then compound 1; then compound 3.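

Exchanging the whole group on the saturated chain carbon bound to a saturated ring carbon moves the number in this assay upward, where the earlier step changed only a substituent on the piperidine ring and moved it down. With (thiophen-2-yl)sulfanyl in place of piperidin-1-yl, the number is higher (a number 1.19 log units higher from compound 1 to compound 3 (beyond the scatter)), and with the same group in place of 4-((methoxycarbonyl)methyl)piperidin-1-yl, it is also higher (a number 2.51 log units higher from compound 2 to compound 3 (beyond the scatter)), so compound 3 stands highest of the three. No supporting evidence bears on the reason for these steps.

The compounds shown do not separate the contribution of the sulfur link from that of the thiophene ring, which phenylsulfanyl or (thiophen-2-yl)oxy at this position would address. As far as these compounds go, how a morpholin-4-yl group or a carboxylic acid in place of the methyl ester would read here also stays open.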